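Series notes: amine replacements on the shared core

The source may report more compounds than this note shows. Statements on the series, on what has been measured and on what is new or still open speak of the compounds shown alone.

Measured so far:
- Compound 1 `Fc1cccnc1Nc1ncc(-c2cnc3ccc(N4CCNCC4)nn23)cn1`: 0.7
- Compound 2 `CN1CCN(c2ccc3ncc(-c4cnc(Nc5ncccc5F)nc4)n3n2)CC1`: 2.2
- Compound 3 `CN1CC[C@H](Nc2ccc3ncc(-c4cnc(Nc5ncccc5F)nc4)n3n2)C1`: 1.5

In a physicochemical assay for lipophilicity (a lower number here means a more polar compound, a higher number a more lipophilic compound), compound 3 stands second highest of the three numbers; its nearest neighbour is compound 2, with a number 0.70 log units lower from compound 2 to compound 3 (beyond the scatter), and the furthest is compound 1, with a number 0.80 log units higher from compound 1 to compound 3 (beyond the scatter). The step from compound 1 to compound 2 is the largest in the set, a number 1.50 log units higher from compound 1 to compound 2 (beyond the scatter).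

Compound 4 `Fc1cccnc1Nc1ncc(-c2cnc3ccc(N[C@H]4CC[C@H](N5CCCC5)CC4)nn23)cn1` differs from compound 3 in one place: 4-(pyrrolidin-1-yl)cyclohexyl in place of 1-methylpyrrolidin-3-yl on a nitrogen on an aromatic ring. The donor and acceptor counts of the leaving and entering groups are the same, while the entering group is larger by five heavy atoms, all carbon, and brings a second non-aromatic ring. For the measured compounds named here, none of the measured steps covers this exact change. The two steps that come closest both add carbon without adding a donor or acceptor: from compound 1 to compound 2, a number 1.50 log units higher from compound 1 to compound 2 (beyond the scatter), and from compound 1 to compound 3, a number 0.80 log units higher from compound 1 to compound 3 (beyond the scatter), each raised this assay beyond the scatter. A rise beyond the scatter is therefore expected here as well, of the order of a number 0.80 log units higher from compound 3 to compound 4 (beyond the scatter). Compound 4 is estimated at 2.3, expected between 1.7 and 2.9.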

Compound 4, distribution coefficient: 1.9
Beside the measured number, compound 4's estimate is 0.40 log units above it, and the stated range covers the measured number.
By their numbers in this assay, from the lowest: compound 1; then compound 3; then compounds 4 and 2 (each within the scatter of the next).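

Within this assay, this is the first change shown that keeps the amino link and alters only the group on a nitrogen on an aromatic ring, and it gives a number 0.40 log units higher from compound 3 to compound 4 (beyond the scatter), with the entering 4-(pyrrolidin-1-yl)cyclohexyl holding 11 heavy atoms against 6 for 1-methylpyrrolidin-3-yl and the same donor and acceptor counts. The number does not simply follow group size across the series: this step is modest, whereas a single methyl in place of hydrogen on an amine nitrogen in a ring gives a number 1.50 log units higher from compound 1 to compound 2 (beyond the scatter). Nothing available explains the size of this step or the contrast between the two changes.

The compounds shown leave open whether the step belongs to the carbon-only six-membered ring or to the pyrrolidin-1-yl group it carries. A morpholine in place of that pyrrolidin-1-yl group, or an open-chain hexyl group on the same nitrogen, would separate these two parts of the change.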